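Amide substituent change from compound 1 to compound 3

The source may report more compounds than this note shows. Statements on the series, on what has been measured and on what is new or still open speak of the compounds shown alone.

Measured so far in a physicochemical assay for solubility, read by HPLC, in simulated intestinal fluid, with a stated time of 16 h, at pH 6.5, tested at 2.5 mg/mL; a higher number here means a more soluble compound, a lower number a less soluble compound
- compound 1 `CNC(=O)c1cc(C(=O)N[C@H]2[C@@H]3C[C@H](O)C[C@@H]32)cc2c1OC[C@@]2(C)c1ccccc1` gives 539 ug/mL
- compound 2 `CNC(=O)c1cc(C(=O)N[C@H]2[C@@H]3COC[C@@H]32)cc2c1OC[C@@]2(C)c1ccccc1` gives 80 ug/mL

Compound 1 holds the higher of the two numbers, with 539 ug/mL as its value. Compound 3 `CNC(=O)c1cc(C(=O)NC2CC2)cc2c1OC[C@@]2(C)c1ccccc1` has not been measured and keeps the core of compound 1. Its change is a group of 3 heavy atoms (3 carbon; one three-membered non-aromatic ring of carbon only) in place of a group of 7 heavy atoms (6 carbon, 1 oxygen; one three-membered non-aromatic ring of carbon only, one five-membered non-aromatic ring of carbon only), on an amide-type nitrogen and cyclopropyl is the group that enters. Among the measured compounds shown here, the one measured step on that amide-type nitrogen is a 6.7-fold lower number from compound 1 to compound 2 (0.83 log units; beyond the scatter) and it is the only support for what follows. A lower number in this assay is therefore expected, of similar size to that step or slightly larger, though a single step is thin support. The estimate amounts to a 9.0-fold lower number from compound 1 to compound 3 (0.95 log units; beyond the scatter) as the expected step. In this assay compound 3 is estimated at 60 ug/mL with 15 ug/mL to 220 ug/mL as its expected range.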

Compound 3, solubility: 585 ug/mL
For compound 3 the middle estimate is 9.8-fold (0.99 log units) below the measured one; the measured number lies above the stated range.
By their numbers in this assay, from the lowest: compound 2; then compounds 1 and 3 (each within the scatter of the next).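

On the amide-type nitrogen, this assay records a 1.1-fold higher number from compound 1 to compound 3 (0.04 log units; within the scatter) when cyclopropyl enters, so the group of 7 heavy atoms, with its 1 hydrogen-bond donor, 1 hydrogen-bond acceptor and 4 defined stereocentres, is not required to hold this reading. With a 7.3-fold higher number from compound 2 to compound 3 (0.86 log units; beyond the scatter) on the same nitrogen, the count of heavy atoms does not order the series: the group of 6 heavy atoms carries the low number, while the groups of 3 and 7 heavy atoms do not, and it goes against any trend with group size. Nothing shown accounts for these differences.

Open, from the compounds shown here alone, is how an amine, a carboxylic acid or a longer alkyl chain on this amide-type nitrogen would read in this assay on the shared core. Also open, going by these compounds, is whether other small rings would track cyclopropyl.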